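The source may report more compounds than this note shows. Statements on the series, on what has been measured and on what is new or still open speak of the compounds shown alone.

Measured in a functional assay on A549 cells (Homo sapiens) for inhibition, read by MTT assay, with a stated time of 72 h; a higher number here means a weaker inhibitor, a lower number a stronger inhibitor:
compound 1 `CNc1nc(C)c(C(=O)N/N=C/c2ccccc2C(F)(F)F)s1` gives > 100 ug/mL, which is a limit of the assay rather than a number.
compound 2 `CN(C(=O)NC(=O)c1cccc(C(F)(F)F)c1)c1nc(C(F)(F)F)c(C(=O)N/N=C/c2ccc(C(F)(F)F)cc2)s1` gives 6.2 ug/mL.
compound 3 `CN(C(=O)NC(=O)c1cccc(C(F)(F)F)c1)c1nc(C(F)(F)F)c(C(=O)N/N=C/c2ccccc2C(F)(F)F)s1` gives 12.1 ug/mL.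

Compound 3 stands highest of the two numbers in this assay, with compound 2 close by. For the measured compounds named here, the only step among the measured numbers, a 2.0-fold higher number from compound 2 to compound 3 (0.29 log units; within the scatter), lies within the scatter. Compound 4 `CN(C(=O)NC(=O)c1ccc(C(F)(F)F)cc1)c1nc(C(F)(F)F)c(C(=O)N/N=C/c2ccccc2C(F)(F)F)s1` is compound 3 with 4-(trifluoromethyl)phenyl in place of 3-(trifluoromethyl)phenyl on a carbonyl carbon. That one measured step also moved a trifluoromethyl around a phenyl ring, though on the carbon with a double bond to nitrogen rather than on the carbonyl carbon, and it stayed within the scatter. Nothing here therefore points to a step beyond the scatter in either direction in this assay. Compound 4 is thus expected at 10 ug/mL (range 4 ug/mL to 30 ug/mL). That means an expected step of a 1.2-fold lower number from compound 3 to compound 4 (0.08 log units; within the scatter).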

Compound 4, half-maximal inhibitory concentration: 6.68 ug/mL
For compound 4 the middle estimate is 1.5-fold (0.18 log units) above the measured one, and the stated range covers the measured number.
By their numbers in this assay, from the lowest: compounds 2, 4 and 3 (each within the scatter of the next). At a limit, above all of these: compound 1.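

At the carbonyl carbon, 4-(trifluoromethyl)phenyl in place of 3-(trifluoromethyl)phenyl gave a 1.8-fold lower number from compound 3 to compound 4 (0.26 log units; within the scatter) in this assay. This place now has a measured step of its own, and, like the earlier change on the carbon with a double bond to nitrogen, that step stays within the scatter. No measurement shown bears on this step. On these data alone, it remains open whether a phenyl carrying an amine or a carboxylic acid instead of the trifluoromethyl, on that same carbonyl carbon, would give a step beyond the scatter.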